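Swapping Iodo for Isobutyl on the Aryl Ring

This account rests on a few compounds, and the source may have more. Where it says the series, first, only, none or still open, it means among the compounds named here.

Two sulfonamides built on one shared core have been tested in a functional assay on MCF7 cells (Homo sapiens) for antiproliferative activity, read by sulforhodamine B assay, with a stated time of 48 h; on this read-out higher numbers stand for weaker inhibition and lower numbers for stronger inhibition. Compound 1 `Cc1ccc(NS(=O)(=O)c2ccc(N3CCNC3=O)cc2)cc1C` gives 230 nM. For the measured compounds named here, compound 2 `O=C1NCCN1c1ccc(S(=O)(=O)Nc2ccc(I)cc2)cc1` gives 600 nM, the higher of the two numbers and therefore the weaker inhibitor; the single measured step, a 2.6-fold higher number from compound 1 to compound 2 (0.42 log units; beyond the scatter), accompanies 4-iodophenyl in place of 3,4-dimethylphenyl on the sulfonamide nitrogen. The unmeasured compound 3 `CC(C)Cc1ccc(NS(=O)(=O)c2ccc(N3CCNC3=O)cc2)cc1` keeps the core of compound 2 and differs on the aryl ring alone: isobutyl in place of iodo on an aromatic carbon. Going by the values given here, only that one measured step bears on this change, and it was modest. It shows that the ring carrying methyl groups went with the lower number, while the ring carrying iodine went with the higher one; isobutyl, like methyl, is a carbon chain, though a longer one than either methyl of compound 1. The expectation for compound 3 is therefore a return toward a lower number, a 1.7-fold lower number from compound 2 to compound 3 (0.23 log units; within the scatter), while a step that stays within the scatter cannot be ruled out. Compound 3 is estimated at 350 nM in this assay, with a range from 120 nM to 1000 nM.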

Compound 3, half-maximal inhibitory concentration: > 1000 nM
Compound 3 gave a limit, no number; the forecaster's own chance of this, stated with the estimate: 3%; middle value at least 2.8-fold (0.45 log units) away from the limit.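

Compound 3 gives no number in this assay, only a limit: the limit of > 1000 nM in this assay, at which 1 of the 3 values shown sits.

As far as these compounds go, the step reads an at least 1.6-fold higher number from compound 2 to compound 3 (0.22 log units; that floor lies within the scatter) and sets only a floor on the gap, so its true size stays unknown. Even so, isobutyl in place of iodo on this aromatic carbon, para to a large group, brings no return toward a lower number, which the earlier pair could not show: with only compound 1 and compound 2 in hand, a carbon chain here might have been enough to bring the number down, and compound 3 shows that carrying one at this place does not ensure that.

The compounds shown leave open whether a shorter chain such as ethyl, or a different kind of group such as methoxy or an amine, on this same aromatic carbon would give a lower number than iodo does. They also offer no measured reason for the result, so what separates isobutyl from iodo here remains an open question.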